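A Terminal Hydroxyl Traded for a Terminal Alkene

A few compounds are considered here, and "the series" means these few. Any claim that something is new, unique, unknown or untested is made for them only; others in the source may bear on it.

Measured so far:
compound 1 `O=S(=O)(/C=C/c1ccc(O)c(O)c1)CCCCCCCO`: 5900 nM
compound 2 `CC(C)(C)OC(=O)N1CCCC1CS(=O)(=O)/C=C/c1ccc(O)c(O)c1`: 7100 nM

In a functional assay, read by fluorescence and spectrophotometry, with a stated time of 1 h (on this read-out higher numbers stand for an effect only at larger amounts of compound and lower numbers for an effect already at smaller amounts), compound 1 gives 5900 nM. Among the measured compounds shown here, compound 2 gives 7100 nM, a number that lies within the usual scatter of the one for compound 1, so the two cannot be told apart. Compound 3 `C=CCCCCCS(=O)(=O)/C=C/c1ccc(O)c(O)c1` differs from compound 1 by vinyl in place of 2-hydroxyethyl on a saturated chain carbon, five bonds along the chain from a sulfonyl sulfur. For the measured compounds named here, no pair of measured compounds shows a change of this kind, so nothing measured here points in either direction. The step from compound 1 to compound 3 is expected to be small, a 1.1-fold lower number from compound 1 to compound 3 (0.03 log units; within the scatter), with no direction beyond the scatter. Compound 3 is therefore expected to give 5500 nM, with a range from 2000 nM to 15000 nM.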

Compound 3, half-maximal effective concentration: 7100 nM
Compound 3: the middle estimate sits 1.3-fold (0.11 log units) below what was measured, and the stated range covers the measured number.
By their numbers in this assay, from the lowest: compounds 1, 2 and 3 (each within the scatter of the next).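

In this assay, vinyl in place of 2-hydroxyethyl on a saturated chain carbon, five bonds along the chain from a sulfonyl sulfur, gives a 1.2-fold higher number from compound 1 to compound 3 (0.08 log units; within the scatter), so compound 1 and compound 3 cannot be told apart. At this position, 2-hydroxyethyl carries a hydrogen-bond donor and acceptor and vinyl carries neither, yet the numbers do not separate the two compounds. No supporting measurement offers an explanation for this result. From the compounds shown here alone, whether an amine or a carboxylic acid on that same carbon, or a longer chain, would give a step beyond the scatter remains open.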